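Compound 3 to compound 4: trifluoromethoxy for trifluoromethyl

The source may report more compounds than this note shows. Statements on the series, on what has been measured and on what is new or still open speak of the compounds shown alone.

In an ADME assay on MRC5 cells (Homo sapiens) for cytotoxicity, read by fluorescence, with a stated time of 72 h (on this read-out lower numbers stand for stronger inhibition and higher numbers for weaker inhibition), compound 3 `CC1(COc2ccc(-c3ccc(C(F)(F)F)cc3)cn2)Cn2cc([N+](=O)[O-])nc2O1` gives > 64000 nM as a limit of the assay, not a number. Compound 2 `CC1(COc2ccc(-c3ccc(F)cc3)cn2)Cn2cc([N+](=O)[O-])nc2O1` likewise gives > 64000 nM as a limit. Among the measured compounds shown here, the only measured step is a step that the two limits leave unreadable from compound 2 to compound 3 and offers no size to carry forward, while the series sits largely at the limit of > 64000 nM in this assay, at which 2 of the 3 values shown sit, in this reading. Compound 4 `CC1(COc2ccc(-c3ccc(OC(F)(F)F)cc3)cn2)Cn2cc([N+](=O)[O-])nc2O1` brings trifluoromethoxy in place of trifluoromethyl on an aromatic carbon as its change from compound 3. For the measured compounds named here, the sole measured compound with trifluoromethoxy is compound 1 `O=[N+]([O-])c1cn2c(n1)OC(COc1ccc(-c3ccc(OC(F)(F)F)cc3)cn1)C2` at 47000 nM in this assay and this value guides the expectation for compound 4. The estimated step is an at least 1.1-fold lower number from compound 3 to compound 4 (0.06 log units; that floor lies within the scatter) toward stronger inhibition, if readable at all. For compound 4 the expected value is 55000 nM with an estimated range of 30000 nM to 100000 nM in this assay overall.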

Compound 4, half-maximal inhibitory concentration: > 64000 nM
Compound 4 was reported as a limit; the forecaster's own chance of this, stated with the estimate: 60%; middle value at least 1.1-fold (0.06 log units) away from the limit.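

In this assay, trifluoromethoxy on this aromatic carbon gives a limit, as fluoro and trifluoromethyl do, so the steps among compound 2, compound 3 and compound 4 cannot be read. Among the compounds shown here, with trifluoromethoxy held fixed, the methyl on the saturated ring carbon gives the one readable comparison, an at least 1.3-fold higher number from compound 1 to compound 4 (0.13 log units; that floor lies within the scatter), so no real change can be claimed from it. Compound 1 is the only compound off the limit: the limit of > 64000 nM in this assay, at which 3 of the 4 values shown sit.

Any true difference among the three aromatic substituents stays open. So does the read-out with an amine or a carboxylic acid at this aromatic carbon.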